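Methoxy for bromo on two related cores

A few compounds are considered here, and "the series" means these few. Any claim that something is new, unique, unknown or untested is made for them only; others in the source may bear on it.

Compound 1 `Brc1ccc(Cc2nnc(Cn3nnc4ccccc43)o2)cc1` and compound 2 `COc1ccc(Cc2nnc(Cn3nnc4ccccc43)o2)cc1` share one core; compound 3 `Brc1ccc(-c2nnc(Cn3nnc4ccccc43)o2)cc1` and compound 4 `COc1ccc(-c2nnc(Cn3nnc4ccccc43)o2)cc1` share another. The difference between the two cores is not broken down here. In a functional assay on HepG2 cells (Homo sapiens) for antiproliferative activity, read by MTT assay, with a stated time of 24 h (a lower number here means a stronger inhibitor, a higher number a weaker inhibitor), compound 1 gives 357000 nM, and compound 2 gives 357000 nM. The change from compound 1 to compound 2 is methoxy in place of bromo on an aromatic carbon, and the step it made was no change at the digits printed from compound 1 to compound 2 (within the scatter). Compound 3 gives 438000 nM in this assay; this value and those of compound 1 and compound 2 lie within the scatter of one another, so no order among the three is read. Compound 4 has not been measured. It differs from compound 3 by methoxy in place of bromo on an aromatic carbon, the same change as that from compound 1 to compound 2, at a place described in the same words. The expected step of a 1.0-fold higher number from compound 3 to compound 4 (0.00 log units; within the scatter) is set beside the measured no change at the digits printed from compound 1 to compound 2 (within the scatter); it rests on that single step on a different core, so the expectation is loose. For compound 4 in this assay a value of 440000 nM is expected, with a range from 200000 nM to 950000 nM.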

Compound 4, half-maximal inhibitory concentration: 477000 nM
Compound 4: middle estimate off by 1.1-fold (0.04 log units), on the low side; the range from low to high includes it.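

In this assay, methoxy in place of bromo on an aromatic carbon gave a 1.1-fold higher number from compound 3 to compound 4 (0.04 log units; within the scatter), so on this core too the change produced no step beyond the scatter. Set side by side, the two steps agree: the same change on two cores in this assay, no change at the digits printed (within the scatter) from compound 1 to compound 2 and a 1.1-fold higher number (0.04 log units; within the scatter) from compound 3 to compound 4, 1.1-fold (0.04 log units) apart, within the scatter of two such steps. This shows that the change was equally without a readable step on the core of compound 1 and the core of compound 3, but it rests on one pair per core, and since neither step departs from the scatter, it does not show that a real shift would carry from one core to the other.

The compounds shown leave open whether any other group in the same place, such as an amine, a carboxylic acid or a nitrile, would give a step beyond the scatter in this assay. They also leave open whether such a step, if found on one core, would appear at a similar size on the other.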